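This account rests on a few compounds, and the source may have more. Where it says the series, first, only, none or still open, it means among the compounds named here.

In a functional assay on HepG2 cells (Homo sapiens) for inhibition, read by fluorescence and resazurin assay, with a stated time of 72 h (on this read-out higher numbers stand for weaker inhibition and lower numbers for stronger inhibition), compound 1 (`O=C(Nc1ccccc1)Nc1cccc(Nc2nccc(Nc3ccc4nc[nH]c4c3)n2)c1`) gives 11000 nM as its half-maximal inhibitory concentration. Compound 2 (`Cc1ccc(Nc2nccc(Nc3ccc4cn[nH]c4c3)n2)cc1NC(=O)Nc1ccccc1`) gives 8900 nM on the same read-out and compound 3 (`COc1ccc(NC(=O)Nc2ccccc2)cc1Nc1nccc(Nc2ccc3cn[nH]c3c2)n1`) gives 6500 nM there, so compound 1 stands within the scatter of both. Compound 4 (`O=C(Nc1ccccc1)Nc1cccc(Nc2nccc(Nc3ccc4cc[nH]c4c3)n2)c1`) differs from compound 1 in one place (1H-indol-6-yl in place of 1H-benzimidazol-6-yl on a nitrogen on an aromatic ring), with 1H-indol-6-yl in place of 1H-benzimidazol-6-yl on a nitrogen on an aromatic ring. Among the measured compounds shown here, no measured pair shows this change, and no step beyond the scatter is expected in this assay in either direction. The estimated step of a 1.5-fold lower number from compound 1 to compound 4 (0.17 log units; within the scatter) is expected to stay within that scatter. Compound 4 is estimated at 7500 nM with an expected range from 3000 nM to 19000 nM in this measurement.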

Compound 4, half-maximal inhibitory concentration: 3200 nM
For compound 4 the middle estimate is 2.3-fold (0.37 log units) above the measured one; low and high end bracket the measured number.
By their numbers in this assay, from the lowest: compound 4; then compounds 3, 2 and 1 (each within the scatter of the next).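

In this assay, among the compounds shown here, 1H-indol-6-yl in place of 1H-benzimidazol-6-yl on a nitrogen on an aromatic ring gives a 3.4-fold lower number from compound 1 to compound 4 (0.54 log units; beyond the scatter), the only step in this set that lies beyond the scatter. It shows that this position responds to the group it carries, with stronger inhibition after one ring nitrogen gives way to carbon and the hydrogen-bond acceptor count of the group falls. The data offer no explanation for this step. The compounds shown leave open what a smaller group such as pyridinyl would give at this place, and whether the step holds with a methyl or methoxy group elsewhere on the molecule.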